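The compounds below may be only part of what the source reports. "The series", "measured", "known", "first", "only" and "open" are said of these compounds alone.

Of the compounds shown here, two of a shared core have been measured in a functional assay on HeLa cells (Homo sapiens) for cytotoxicity, read by MTT assay, with a stated time of 2 days, tested at 1 uM; a higher number here means a weaker effect of the compound at the concentration tested, a lower number a stronger effect. Compound 1 `CC(=O)c1cc(-c2ccccc2)cc2cc(-c3ccc(F)cc3)[nH]c12` gives 85.1% there. Compound 2 `CC(=O)c1cc(/C=C/c2ccc(F)cc2)cc2cc(-c3ccccc3)[nH]c12` gives 70%, the lowest of the two numbers, a gap from compound 1 that lies beyond the usual scatter. Compound 3 `CC(=O)c1cc(/C=C/c2ccc(F)cc2)cc2cc(-c3ccc(F)cc3)[nH]c12` is not yet measured; it differs from compound 2 by fluoro in place of hydrogen on an aromatic carbon. For this small change no step beyond the scatter is expected, so the step from compound 2 to compound 3 is estimated at a number 2 percentage points lower from compound 2 to compound 3 (within the scatter). In this assay compound 3 is expected to give about 68%, within 52% to 84%.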

Compound 3, a percentage reported as activity, at one concentration (the size of the read-out at that concentration, not a potency): 53.7%
The estimate for compound 3 lay 14.3 percentage points above the measured number, within the range that was stated.
By their numbers in this assay, from the lowest: compound 3; then compound 2; then compound 1.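

In this assay the change from phenyl to 4-fluorophenyl gives a number 16.3 percentage points lower from compound 2 to compound 3 (beyond the scatter) with the 2-(4-fluorophenyl)ethenyl group in place, so this position on the ring affects the read-out. With 4-fluorophenyl kept, 2-(4-fluorophenyl)ethenyl in place of phenyl gives a number 31.4 percentage points lower from compound 1 to compound 3 (beyond the scatter) as the larger of the two steps. The data shown offer no explanation for either step.

From the compounds shown here alone, whether an amine or a methoxy group at this position would lower the number further remains open. So does the effect of a longer chain in place of the ethenyl link.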